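Spiro series: amide side-chain variation, compound 4

This account rests on a few compounds, and the source may have more. Where it says the series, first, only, none or still open, it means among the compounds named here.

Measured compounds:
compound 1, `CC(C)(C)c1ccc(C(=O)N2CCC3(CC2)C(=O)N(CC(=O)N2CCN(S(C)(=O)=O)CC2)CN3c2ccccc2)cc1`: 19000 nM
compound 2, `CC(C)(C)OC(=O)NCCCCCNC(=O)CN1CN(c2ccccc2)C2(CCN(C(=O)c3ccc(C(C)(C)C)cc3)CC2)C1=O`: 13700 nM
compound 3, `CC(C)(C)c1ccc(C(=O)N2CCC3(CC2)C(=O)N(CC(=O)N2CCCC(CO)C2)CN3c2ccccc2)cc1`: 8200 nM

All three share one core and differ only in the amide attached through a methylene to the ring nitrogen. In an assay on HEK293 cells for displacement of a labelled ligand from NPC1-like intracellular cholesterol transporter 1 (Homo sapiens) (on this read-out higher numbers stand for weaker inhibition and lower numbers for stronger inhibition), compound 3 gives the lowest number of the three, though compound 2 sits within the usual scatter of it, so no order between compound 2 and compound 3 can be read. For the measured compounds named here, the one single-point step measured so far is a 2.3-fold lower number from compound 1 to compound 3 (0.36 log units; beyond the scatter), a modest change.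

Compound 4, `CC(C)(C)c1ccc(C(=O)N2CCC3(CC2)C(=O)N(CC(=O)NCCCCN)CN3c2ccccc2)cc1`, is not yet measured. It differs from compound 3 in one place: (4-aminobutyl)amino in place of 3-(hydroxymethyl)piperidin-1-yl on a carbonyl carbon. The change opens the ring to a chain, as compound 2 also carries a chain amide. Going by the values given here, no measured step bears directly on this exact exchange; the only guide is that compound 2 and compound 3 lie within scatter of each other, and the one measured step is modest. Expected, then, is no step beyond the scatter, perhaps a slightly higher number: a 1.3-fold higher number from compound 3 to compound 4 (0.13 log units; within the scatter). The estimate for compound 4 in this assay is 11000 nM, with a range of 4000 nM to 30000 nM.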

Compound 4, half-maximal inhibitory concentration: 14500 nM
For compound 4 the middle estimate is 1.3-fold (0.12 log units) below the measured one; measured number inside the range.
By their numbers in this assay, from the lowest: compounds 3, 2, 4 and 1 (each within the scatter of the next, the first and the last beyond it).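

In this assay, the amide position on the carbonyl carbon now holds an open chain with a free terminal amine, and replacing the ring of compound 3 with (4-aminobutyl)amino gives a 1.8-fold higher number from compound 3 to compound 4 (0.25 log units; within the scatter), so this exchange of ring for chain has no readable effect. The two other comparisons read the same way: removing the ((tert-butoxycarbonyl)amino)methyl end in favour of amino gives a 1.1-fold higher number from compound 2 to compound 4 (0.02 log units; within the scatter), and (4-aminobutyl)amino in place of 4-(methylsulfonyl)piperazin-1-yl gives a 1.3-fold lower number from compound 1 to compound 4 (0.12 log units; within the scatter), so compound 4 cannot be separated from any of the three earlier compounds, although compound 1 and compound 3 are separated by a 2.3-fold lower number from compound 1 to compound 3 (0.36 log units; beyond the scatter). Nothing available bears on why these numbers fall as they do.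

Still open, as far as these compounds go, is whether a carboxylic acid or a hydroxyl group at the end of the chain, or a shorter or longer chain, would give a step beyond the scatter from compound 4. Also open, from the compounds shown here alone, is whether a piperidine carrying aminomethyl in place of hydroxymethyl would separate the effect of the ring from that of the terminal group.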